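The compounds below may be only part of what the source reports. "The series", "measured", "known", "first", "only" and "open" are said of these compounds alone.

In a functional assay on A549 cells (Homo sapiens) for inhibition, read by MTT assay, with a stated time of 96 h (on this read-out higher numbers stand for weaker inhibition of growth and lower numbers for stronger inhibition of growth), compound 1 `O=C(OCc1ccccc1)SCCCCCCNC(=O)c1cc(-c2ccncc2)n[nH]1` gives 13400 nM and compound 2 `C=CCOC(=O)SCCCCCCNC(=O)c1cc(-c2ccncc2)n[nH]1` gives 15200 nM as its value, a pair within the scatter (a 1.1-fold higher number from compound 1 to compound 2 (0.05 log units; within the scatter)). Compound 3 `CCC(=O)SCCCCCCNC(=O)c1cc(-c2ccncc2)n[nH]1` gives > 50000 nM as a limit of the assay and not a number. Its place in the series is thus only a bound (the limit of > 50000 nM in this assay, at which 1 of the 3 values shown sits) and not a rank.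

Compound 4 `CC(=O)SCCCCCCNC(=O)c1cc(-c2ccncc2)n[nH]1` differs from it by hydrogen in place of methyl on a saturated chain carbon bound to a carbonyl carbon, propanoyl to acetyl (hydrogen in place of methyl on a saturated chain carbon bound to a carbonyl carbon). Among the compounds with values here, two measured steps bear on this only loosely (an at least 3.7-fold higher number from compound 1 to compound 3 (0.57 log units; beyond the scatter); an at least 3.2-fold higher number from compound 2 to compound 3 (0.51 log units; beyond the scatter)), and both put ethyl in place of benzyloxy or allyloxy on a carbonyl carbon. Both are bounds, and neither is a change from ethyl to methyl, so no step beyond the scatter is expected in this assay for this pair. The estimated step is small (a number no higher from compound 3 to compound 4 (the limit leaves the size open)) and another limit reading is likely. For compound 4 the expected value is 50000 nM within an estimated range from 20000 nM to 100000 nM as the working figure.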

Compound 4, concentration for 50% growth inhibition: 18000 nM
Beside the measured number, compound 4's estimate is 2.8-fold (0.44 log units) above it; measured number below the stated range.
By their numbers in this assay, from the lowest: compounds 1, 2 and 4 (each within the scatter of the next). At a limit, above all of these: compound 3.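

In this assay the change from propanoyl to acetyl is not silent, with an at least 2.7-fold lower number from compound 3 to compound 4 (0.44 log units; beyond the scatter), so a single methyl on a saturated chain carbon bound to a carbonyl carbon separates a limit reading from a measured one. Acetyl also stands level with the benzyloxy and allyloxy groups on the carbonyl carbon, with a 1.3-fold higher number from compound 1 to compound 4 (0.13 log units; within the scatter) and a 1.2-fold higher number from compound 2 to compound 4 (0.07 log units; within the scatter), so the loss seen with ethyl on that carbon is not shared by methyl. The true size of the step from propanoyl to acetyl stays open, because compound 3 is held only by a limit: the limit of > 50000 nM in this assay, at which 1 of the 4 values shown sits.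

The compounds shown leave open whether the reading for ethyl is peculiar to ethyl or the start of a fall with chain length. A longer chain on the carbonyl carbon, such as butyl, or an amine in that place would help to settle this.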